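Cytotoxicity of a Bridged Amino Acid Series on Canine Kidney Cells

A few compounds are considered here, and "the series" means these few. Any claim that something is new, unique, unknown or untested is made for them only; others in the source may bear on it.

Three compounds sharing a bridged bicyclic carboxylic acid attached through an amine to a fused heteroaromatic core were tested in an ADME assay on MDCK cells (Canis lupus familiaris) for cytotoxicity, read by CCK-8 assay, with a stated time of 5 days; on this read-out lower numbers stand for higher toxicity in this test and higher numbers for lower toxicity in this test. Compound 1 `O=C(O)[C@H]1C2CCC(CC2)[C@@H]1Nc1nc(-c2c[nH]c3ncc(F)cc23)nc2ccsc12` gives 1500 nM in this assay. Compound 3 `O=C(O)[C@H]1C2CCC(CC2)[C@@H]1Nc1nc(-c2n[nH]c3ncc(F)cc23)nc2ccsc12` differs from compound 1 by a group of 10 heavy atoms (6 carbon, 3 nitrogen, 1 fluorine; one five-membered aromatic ring with 2 hetero atoms, one six-membered aromatic ring with 1 hetero atom) in place of a group of 10 heavy atoms (7 carbon, 2 nitrogen, 1 fluorine; one five-membered aromatic ring with 1 hetero atom, one six-membered aromatic ring with 1 hetero atom), on an aromatic carbon. In this assay compound 3 gives 200 nM; the step of a 7.5-fold lower number from compound 1 to compound 3 (0.88 log units; beyond the scatter). Compound 2 `O=C(O)[C@H]1C2CCC(CC2)[C@@H]1Nc1nc(-c2c[nH]c3ncc(F)cc23)nc2c1SCC2` has a different core, and the difference between the two cores is not broken down here; in this assay compound 2 gives 4500 nM, the highest of the three numbers.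

Compound 4 `O=C(O)[C@H]1C2CCC(CC2)[C@@H]1Nc1nc(-c2n[nH]c3ncc(F)cc23)nc2c1SCC2` has not yet been measured. It carries the same change relative to compound 2 that compound 3 carries relative to compound 1, namely (a group of 10 heavy atoms (6 carbon, 3 nitrogen, 1 fluorine; one five-membered aromatic ring with 2 hetero atoms, one six-membered aromatic ring with 1 hetero atom) in place of a group of 10 heavy atoms (7 carbon, 2 nitrogen, 1 fluorine; one five-membered aromatic ring with 1 hetero atom, one six-membered aromatic ring with 1 hetero atom), on an aromatic carbon). Since the place is described in the same words in both pairs, the change is the same. Compound 4 is expected to fall in this assay by a step of about a 7.5-fold lower number from compound 2 to compound 4 (0.88 log units; beyond the scatter), resting on the move from compound 1 to compound 3, a 7.5-fold lower number from compound 1 to compound 3 (0.88 log units; beyond the scatter), applied to compound 2 at 4500 nM. Compound 4 is therefore estimated at 600 nM, with a range from 200 nM to 1800 nM.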

Compound 4, half-maximal cytotoxic concentration: 4900 nM
The estimate for compound 4 lay 8.2-fold (0.91 log units) below the measured number, and the stated range ends below it.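

In this assay the change gave a 1.1-fold higher number from compound 2 to compound 4 (0.04 log units; within the scatter), so the drop seen on the core of compound 1 did not recur on the core of compound 2. Set side by side, the two steps disagree: the same change on two cores in this assay, a 7.5-fold lower number (0.88 log units; beyond the scatter) from compound 1 to compound 3 and a 1.1-fold higher number (0.04 log units; within the scatter) from compound 2 to compound 4, 8.2-fold (0.91 log units) apart, beyond the scatter of two such steps. This shows that, for these two cores, the step seen on one core did not predict the step on the other, so a step for this change cannot safely be carried between them; it does not show which feature of the cores accounts for the difference, nor why, and it rests on one pair of compounds for each core.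

The compounds shown leave open how the same change would behave on any third core, and so which of the two steps would be the more typical. They also leave open whether the disagreement would persist with chlorine in place of the fluorine, or with an amide in place of the carboxylic acid.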